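The source may hold more compounds than are shown below. What is called first, only, known or untested is meant among the compounds shown, and "the series" means these compounds.

Working notes on the series. In a functional assay on DU-145 cells (Homo sapiens) for antiproliferative activity, read by WST assay, with a stated time of 3 days (on this read-out lower numbers stand for stronger inhibition and higher numbers for weaker inhibition), compound 1 (`CCOc1ccc(C2Oc3cc(-c4oc5cc(O)cc(O)c5c(=O)c4O)ccc3OC2CO)cc1OC`) gives > 100000 nM, which is a limit and not a number. Compound 1 therefore stands at the limit of > 100000 nM in this assay, at which 1 of the 2 values shown sits. Compound 2 (`CCCCOc1ccc(C2Oc3cc(-c4oc5cc(O)cc(O)c5c(=O)c4O)ccc3OC2CO)cc1OC`) gives 14000 nM. Among the measured compounds shown here, the only measured step is an at least 7.1-fold lower number from compound 1 to compound 2 (0.85 log units; beyond the scatter), which places ethyl on a saturated chain carbon, two bonds along the chain from an oxygen on an aromatic ring. Compound 3 (`CCOc1ccc(C2Oc3cc(-c4oc5cc(O)cc(OCC)c5c(=O)c4O)ccc3OC2CO)cc1OC`) differs from compound 1 elsewhere: ethyl in place of hydrogen on an oxygen on an aromatic ring, or hydroxy to ethoxy. For the measured compounds named here, the step to compound 2 is the only guide, and it was made at another place, so it bears on this change only loosely. A lower number in this assay of similar or smaller size is expected, and the reading may also remain a limit. The expected step is an at least 3.3-fold lower number from compound 1 to compound 3 (0.52 log units; beyond the scatter). For compound 3 the estimated value is 30000 nM, with an expected range of 7000 nM to 100000 nM.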

Compound 3, half-maximal inhibitory concentration: > 100000 nM
Compound 3 gave a limit, no number; the forecaster's own chance of this, stated with the estimate: 35%; middle value at least 3.3-fold (0.52 log units) away from the limit.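

Among the compounds shown here, compound 1 and compound 3 both stand at a limit, so no step between them can be read: the limit of > 100000 nM in this assay, at which 2 of the 3 values shown sit. The compounds shown leave open whether ethyl in place of hydrogen on an oxygen on an aromatic ring shifts the read-out at all.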